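Methoxy for methyl on the aryl of compound 2

The source may hold more compounds than are shown below. What is called first, only, known or untested is meant among the compounds shown, and "the series" means these compounds.

Compound 2 `Cc1ccc(N2C(N)=NC(N)=NC23CCCCC3)cc1` is known in an assay for inhibition of Dihydrofolate reductase (Bos taurus), using NADPH (on this read-out lower numbers stand for stronger inhibition and higher numbers for weaker inhibition), only as a limit, > 100000 nM. Compound 1 `NC1=NC2(CCCCC2)N(c2ccccc2)C(N)=N1` likewise gives only a limit in this assay, > 100000 nM. The step that the two limits leave unreadable from compound 1 to compound 2 therefore cannot be read; the limit of > 100000 nM in this assay, at which 2 of the 2 values shown sit, is all that the two values show. Compound 3 `COc1ccc(N2C(N)=NC(N)=NC23CCCCC3)cc1` carries methoxy in place of methyl on an aromatic carbon. Going by the values given here, no measured step bears on this change, and with both known values sitting at a limit no size or direction can be expected for the step from compound 2 to compound 3. Compound 3 is expected at 100000 nM, between 30000 nM and 300000 nM, most likely again reported only as a limit, which means an estimated step of a number no higher from compound 2 to compound 3 (the limit leaves the size open).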

Compound 3, half-maximal inhibitory concentration: > 100000 nM
Compound 3 ended at the assay's limit; the forecaster's own chance of this, stated with the estimate: 85%; the middle value lies on the limit itself.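

Going by these compounds alone, no step among compound 1, compound 2 and compound 3 can be read, because all three stand at one limit: the limit of > 100000 nM in this assay, at which 3 of the 3 values shown sit. From the compounds shown here alone, whether methyl or methoxy on the aromatic carbon alters inhibition, in size or direction, remains open.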